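This account rests on a few compounds, and the source may have more. Where it says the series, first, only, none or still open, it means among the compounds named here.

Measured so far:
- compound 1 `CCOC(=O)c1ccc(/N=N/N(C)C(=O)[C@H](C)NC(C)=O)cc1` — 4.6 h
- compound 2 `CCCC(=O)N[C@@H](C)C(=O)N(C)/N=N/c1ccc(C#N)cc1` — 1.1 h
- compound 3 `C[C@H](NC(=O)c1ccccc1)C(=O)N(C)/N=N/c1ccc(C#N)cc1` — 1.6 h

In an ADME assay on a cell-free system (plasma, Homo sapiens) for metabolic stability, read by HPLC (a lower number here means that the compound disappears faster, a higher number that the compound lasts longer), compound 1 stands highest of the three numbers; compound 3 sits nearest, a step below it that lies beyond the scatter, and compound 2 furthest, also beyond the scatter. Compound 4 `CC(=O)N[C@@H](C)C(=O)N(C)/N=N/c1ccc(C(C)=O)cc1` is the next compound for this assay. It differs from compound 1 in one place: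

methyl in place of ethoxy on a carbonyl carbon

For the measured compounds named here, the only single-change step measured is a 1.5-fold higher number from compound 2 to compound 3 (0.16 log units; within the scatter), which sits on the amide carbonyl and lies within the scatter; it says nothing about the aryl carbonyl that is altered here. Compounds 2 and 3 differ from compound 1 in more than one place, so their lower values cannot be tied to the ring substituent alone. Going by the values given here, there is thus no measured step that bears directly on the ethoxy-to-methyl change, and the expectation rests on compound 1 by itself, with a wide range. The step from compound 1 to compound 4 is expected to be a 1.1-fold higher number from compound 1 to compound 4 (0.04 log units; within the scatter), that is, no change beyond the scatter is assumed. For compound 4 the half-life in this assay is estimated at 5 h, within 2 h to 12 h.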

Compound 4, half-life in the plasma assay: 2.3 h
Estimate against measurement, compound 4: 2.2-fold (0.34 log units) above; low and high end bracket the measured number.
By their numbers in the plasma assay, from the lowest: compounds 2, 3, 4 and 1 (each within the scatter of the next, the first and the last beyond it).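

Working notes on the aryl carbonyl: in the plasma assay, methyl in place of ethoxy on a carbonyl carbon gives a 2.0-fold lower number from compound 1 to compound 4 (0.30 log units; within the scatter), the first step read at this position, as the earlier single-change step sat on the amide carbonyl. In a physicochemical assay for metabolic stability, read by HPLC, in phosphate buffer, at pH 7.7 (on this read-out lower numbers stand for a shorter-lived compound and higher numbers for a longer-lived compound), compound 1 gives 15.7 h and compound 4 gives 13.9 h, which is a 1.1-fold lower number from compound 1 to compound 4 (0.05 log units; within the scatter), so for this pair the ethoxycarbonyl to acetyl change stays within the scatter on both read-outs and neither half-life is shown to depend on the ethoxy group. Nothing on hand gives a reason for either reading.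

Still open, as far as these compounds go, is whether this holds for other groups on the same carbonyl carbon, such as a hydroxyl (the carboxylic acid), an amine (the primary amide) or a longer chain such as propyl in place of methyl. Also open, from the compounds shown here alone, is whether the ethoxy-to-methyl step reads the same when the amide carbonyl carries propyl or phenyl, since compounds 2 and 3 differ from compounds 1 and 4 in more than one place.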